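Swapping methyl for 7-chloroquinolin-4-yl in compound 2

The source may report more compounds than this note shows. Statements on the series, on what has been measured and on what is new or still open speak of the compounds shown alone.

- compound 1 `O=C(NNc1ccnc2cc(Cl)ccc12)c1ccccc1/N=C/c1ccc(Cl)c(Cl)c1` gives 6.22
- compound 2 `COc1ccc(/C=N/c2ccccc2C(=O)NNc2ccnc3cc(Cl)ccc23)cc1OC` gives 4.97

In a physicochemical assay for lipophilicity, measured as octanol-water partition (on this read-out lower numbers stand for lower lipophilicity and higher numbers for higher lipophilicity), compound 2 (4.97) holds the lower of the two numbers. Compound 3 `COc1cc(/C=N/c2ccccc2C(=O)NNc2ccnc3cc(Cl)ccc23)ccc1Oc1ccnc2cc(Cl)ccc12` has not been measured yet. It differs from compound 2 in one place (7-chloroquinolin-4-yl in place of methyl on an oxygen on an aromatic ring): 7-chloroquinolin-4-yl stands in place of methyl on an oxygen on an aromatic ring.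

Among the compounds with values here, no measured step makes this exact exchange. The closest one puts 3,4-dimethoxyphenyl in place of 3,4-dichlorophenyl (a number 1.25 log units lower from compound 1 to compound 2 (beyond the scatter)), and it shows that one exchange of groups can shift the number a long way. That single comparison is thin support, but with a much larger group entering, a large step to a higher number is expected in this assay here. The estimated change is a number 1.93 log units higher from compound 2 to compound 3 (beyond the scatter) (an expectation, not a measurement). For compound 3 the expected value is 6.9 (estimated range 6 to 7.8).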

Compound 3, partition coefficient: 7.74
Compound 3: middle estimate off by 0.84 log units, on the low side; the range from low to high includes it.
By their numbers in this assay, from the lowest: compound 2; then compound 1; then compound 3.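

In this assay, a change at a single oxygen on an aromatic ring, methoxy to (7-chloroquinolin-4-yl)oxy, gives a number 2.77 log units higher from compound 2 to compound 3 (beyond the scatter), so this one position can by itself move the number a long way. The earlier step exchanged a whole 3,4-disubstituted phenyl group, whereas here one methyl with 1 heavy atom gives way to a group with 11 heavy atoms, two aromatic rings and a hydrogen-bond acceptor. Nothing measured here explains why the number rises so far.

With a single exchange at this oxygen, the effect of added size cannot be separated from that of the particular group. A simple phenyl or a longer chain such as butyl on the same oxygen, or a carboxylic acid carried on such a chain, would show how the number responds to other groups there.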